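Benzylsulfanyl extension of the triazole in a diaryl ether series

This account rests on a few compounds, and the source may have more. Where it says the series, first, only, none or still open, it means among the compounds named here.

Measured in a functional assay on the whole organism (strain NMRI) with Mus musculus as the target, with a stated time of 60 min, at a dose of 20 mg/kg by the intraperitoneal route; a lower number here means a weaker effect, a higher number a stronger effect of the compound at the dose given:
compound 1 `S=c1[nH]nc(Cc2ccc(Cl)cc2Oc2ccccc2Cl)[nH]1` gives 159%
compound 2 `CSc1nnc(Cc2ccc(Cl)cc2Oc2ccccc2Cl)[nH]1` gives 170%
compound 3 `CSc1nnc(Cc2ccc(Cl)cc2Oc2ccccc2F)[nH]1` gives 136%

Compound 3 stands lowest of the three in this assay; the nearest number is that of compound 1, the furthest that of compound 2, and both gaps are beyond the scatter. The step of a number 34 percentage points lower from compound 2 to compound 3 (beyond the scatter) is large and comes from fluoro in place of chloro on an aromatic carbon.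

Compound 4 `Fc1ccccc1Oc1cc(Cl)ccc1Cc1nnc(SCc2ccccc2)[nH]1` is not yet measured. It differs from compound 3 by phenyl in place of hydrogen on a saturated chain carbon bound to a sulfur; read one bond further out, methylsulfanyl becomes benzylsulfanyl. Within the data shown here, no measured step covers this benzyl extension. Among the measured compounds shown here, the only step at the same sulfur is a number 11 percentage points higher from compound 1 to compound 2 (beyond the scatter), a modest gain on going from the thione to methylsulfanyl. For the measured compounds named here, since no measured pair shows a larger substituent on that sulfur, no direction beyond the scatter is expected.

The estimate for compound 4 in this assay is therefore 138%, in the range 110% to 168%, a step of a number 2 percentage points higher from compound 3 to compound 4 (within the scatter) expected to lie within the scatter.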

Compound 4, a percentage reported as activity, at one dose (the size of the read-out at that dose, not a potency): 179%
Beside the measured number, compound 4's estimate is 41 percentage points below it; measured number above the stated range.
By their numbers in this assay, from the lowest: compound 3; then compound 1; then compounds 2 and 4 (each within the scatter of the next).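

In this assay, among these compounds, the sulfur side chain proves to be a position that can move the read-out strongly: a number 43 percentage points higher from compound 3 to compound 4 (beyond the scatter) is a large step, whereas the only earlier change at this sulfur, a number 11 percentage points higher from compound 1 to compound 2 (beyond the scatter), was modest. Phenyl in place of hydrogen on the saturated chain carbon bound to the sulfur therefore has an effect printed as large, as is the halogen change in a number 34 percentage points lower from compound 2 to compound 3 (beyond the scatter), so the series now has two sensitive places. No measurement on hand accounts for this gain.

From the compounds shown here alone, whether the gain needs the aromatic ring itself, or would also come with a cyclohexyl group or a plain propyl chain on that sulfur, stays open. Also open, going by these compounds, are the effect of an amine or a carboxylic acid on the benzyl group and whether the gain carries over to the chloro partner of the fluoro ring.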